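Notes on a cyclic carbamate series: side-chain swaps

The source may report more compounds than this note shows. Statements on the series, on what has been measured and on what is new or still open speak of the compounds shown alone.

Measured so far:
compound 1 `CN(CCC#N)C[C@H]1CN(c2ccc(-n3cc(-c4ccccn4)cn3)c(F)c2)C(=O)O1`, 1.9
compound 2 `O=C1O[C@@H](CN2CCC(O)CC2)CN1c1ccc(-n2cc(-c3ccccn3)cn2)c(F)c1`, 1.63
compound 3 `O=C1O[C@@H](Cn2ccnn2)CN1c1ccc(-n2cc(-c3ccccn3)cn2)c(F)c1`, 2

In a physicochemical assay for lipophilicity, read by HPLC, measured as octanol-water partition (on this read-out higher numbers stand for higher lipophilicity and lower numbers for lower lipophilicity), compound 3 stands at the upper end of the three numbers, though a number 0.10 log units higher from compound 1 to compound 3 (within the scatter), and only a number 0.37 log units higher from compound 2 to compound 3 (beyond the scatter). Compound 4 `O=C(NC[C@H]1CN(c2ccc(-n3cc(-c4ccccn4)cn3)c(F)c2)C(=O)O1)C(F)F` differs from compound 3 in one place: ((difluoromethyl)carbonyl)amino in place of 1H-1,2,3-triazol-1-yl on a saturated chain carbon bound to a saturated ring carbon. Among the measured compounds shown here, no measured step carries this amide, but every swap at the same place shifted the read-out little: a number 0.27 log units lower from compound 1 to compound 2 (within the scatter), a number 0.10 log units higher from compound 1 to compound 3 (within the scatter), a number 0.37 log units higher from compound 2 to compound 3 (beyond the scatter). Accordingly the step from compound 3 to compound 4 is expected to stay within the scatter, a number 0.20 log units lower from compound 3 to compound 4 (within the scatter), if anything slightly downward. For compound 4 the estimate in this assay is 1.8, with a range from 1.4 to 2.2.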

Compound 4, partition coefficient: 1.9
The estimate for compound 4 lay 0.10 log units below the measured number, and the stated range covers the measured number.
By their numbers in this assay, from the lowest: compounds 2, 1, 4 and 3 (each within the scatter of the next, the first and the last beyond it).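

In this assay the ((difluoromethyl)carbonyl)amino group, which has no ring, stays within the scatter of all three earlier side chains at this place (a number 0.10 log units lower from compound 3 to compound 4 (within the scatter); a number 0.27 log units higher from compound 2 to compound 4 (within the scatter); no change at the digits printed from compound 1 to compound 4 (within the scatter)). Among the compounds shown here, an open-chain amide therefore joins the amine and triazole side chains in a narrow span, and the only step beyond the scatter remains the one between compound 2 and compound 3. Nothing available explains these steps. On these data alone, whether a carboxylic acid, a primary amine or a longer chain on this saturated chain carbon would stay within the same span remains open.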